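A Shared Aryl Swap on Two Hydroxamate Cores

The source may report more compounds than this note shows. Statements on the series, on what has been measured and on what is new or still open speak of the compounds shown alone.

Compound 1 `COc1ccc(C(=O)c2ccc3c(ccn3Cc3ccc(C(=O)NO)cc3)c2)cc1OC`: 15.5 nM
Compound 2 `O=C(NO)c1ccc(Cn2ccc3cc(C(=O)c4ccc(F)cc4)ccc32)cc1`: 9.25 nM
Compound 3 `COc1ccc(C(=O)c2ccc3c(ccn3S(=O)(=O)c3cccc(/C=C/C(=O)NO)c3)c2)cc1OC`: 1180 nM

All three measured compounds were examined in an assay on isolated protein for inhibition of protein deacetylase HDAC6 (Homo sapiens); a higher number here means a weaker inhibitor, a lower number a stronger inhibitor. Compound 1 and compound 2 share one core and differ by 4-fluorophenyl in place of 3,4-dimethoxyphenyl on a carbonyl carbon; the step between them reads a 1.7-fold lower number from compound 1 to compound 2 (0.22 log units; within the scatter). Compound 3 has the highest number of the three, and its gap to compound 1 and to compound 2 lies beyond the scatter in both cases. The difference between the core of compound 3 and the core of compound 1 is not broken down here.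

Compound 4 `O=C(/C=C/c1cccc(S(=O)(=O)n2ccc3cc(C(=O)c4ccc(F)cc4)ccc32)c1)NO` has not yet been measured in this assay. It differs from compound 3 by 4-fluorophenyl in place of 3,4-dimethoxyphenyl on a carbonyl carbon, the same change that separates compound 1 from compound 2, made at the same place. The step is expected to be small because the matching step earlier read a 1.7-fold lower number from compound 1 to compound 2 (0.22 log units; within the scatter), which was within the scatter, so the expectation is a 1.6-fold lower number from compound 3 to compound 4 (0.20 log units; within the scatter). Compound 4 is therefore estimated at 750 nM, with a likely range from 300 nM to 2000 nM.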

Compound 4, half-maximal inhibitory concentration: 1420 nM
For compound 4 the middle estimate is 1.9-fold (0.28 log units) below the measured one; the range from low to high includes it.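

In this assay, putting 4-fluorophenyl in place of 3,4-dimethoxyphenyl on a carbonyl carbon gave a 1.2-fold higher number from compound 3 to compound 4 (0.08 log units; within the scatter), so on the core of compound 3, as on the core of compound 1, the change stayed within the scatter. Set side by side, the two steps do not differ, and in this small set the change carried from one core to the other without a detectable shift: the same change on two cores in this assay, a 1.7-fold lower number (0.22 log units; within the scatter) from compound 1 to compound 2 and a 1.2-fold higher number (0.08 log units; within the scatter) from compound 3 to compound 4, 2.0-fold (0.30 log units) apart, within the scatter of two such steps This rests on one pair of compounds per core in a single assay, and it shows only that the change was small on these two cores, not that it would stay small on a further core or that either group is better than the other.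

From the compounds shown here alone, how a phenyl bearing an amine or a carboxylic acid would read on that carbonyl carbon remains open on both cores. Also open, going by these compounds, is how much each part of the difference between the core of compound 1 and the core of compound 3 contributes to the number.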